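The compounds below may be only part of what the source reports. "The series", "measured", "known", "first", "only" and "open" are said of these compounds alone.

Compounds measured in a functional assay on the whole organism with Canis familiaris (Canis lupus familiaris) as the target; a higher number here means that more compound is needed for the effect, a lower number that less compound is needed:
Compound 1 `COc1ccc(-c2nc3cc[nH]cc-3n2)cc1`: 1.7 mg/kg
Compound 2 `COc1ccc(-c2nc3cc[nH]cc-3n2)c(OC)c1`: 0.3 mg/kg

Compound 2 holds the lower of the two numbers, at 0.3 mg/kg, so less of it is needed for the effect. The next compound, compound 3 `CCCOc1cc(OC)ccc1-c1nc2cc[nH]cc-2n1`, has not yet been measured. It departs from compound 2 by one change, (ethyl in place of hydrogen on a saturated chain carbon bound to an oxygen on an aromatic ring), which turns a methoxy into a propoxy. Within the data shown here, only one measured step bears on this: a 5.7-fold lower number from compound 1 to compound 2 (0.75 log units; beyond the scatter), where methoxy took the place of hydrogen on an aromatic carbon. That step introduced the very methoxy now being lengthened, and it was modest but beyond the scatter. Among the measured compounds shown here, it shows that this group matters in this assay, but it says nothing about chain length, since no measured pair differs in that way. A small move back towards a higher number therefore seems more likely than a further gain, though it may not clear the scatter. The expected change is a 1.7-fold higher number from compound 2 to compound 3 (0.22 log units; within the scatter). For compound 3 the estimated value is 0.5 mg/kg, with an expected range of 0.15 mg/kg to 1.5 mg/kg.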

Compound 3, dose for half-maximal effect: 1.3 mg/kg
The estimate for compound 3 lay 2.6-fold (0.41 log units) below the measured number, within the range that was stated.
By their numbers in this assay, from the lowest: compound 2; then compounds 3 and 1 (each within the scatter of the next).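

In this assay the result shows that chain length matters at this place, on a saturated chain carbon bound to an oxygen on an aromatic ring: going from methoxy to propoxy gives a 4.3-fold higher number from compound 2 to compound 3 (0.64 log units; beyond the scatter) in this series, whereas the earlier pair showed only that a methoxy differs from hydrogen. Set against the hydrogen of compound 1, the propoxy gives a 1.3-fold lower number from compound 1 to compound 3 (0.12 log units; within the scatter) and so cannot be told apart from it in this assay. The gain seen with the methoxy (a 5.7-fold lower number from compound 1 to compound 2 (0.75 log units; beyond the scatter) for that change) therefore does not extend to the propoxy, and among the compounds shown it belongs to the methoxy alone.

On these data alone, whether an ethoxy would stand with the methoxy or with the propoxy remains open, as does the effect of a longer chain, or of an amine or a carboxylic acid carried on the chain. No measurement shown here accounts for the difference between the methoxy and the propoxy.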